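Chain extension on the shared core: cytotoxicity notes

The compounds below may be only part of what the source reports. "The series", "measured", "known", "first", "only" and "open" are said of these compounds alone.

Compound 1 `CCCCc1cc2cn(COCCO)c(=O)nc2o1` carries a butyl group on an aromatic carbon of the shared core. In a functional assay on HEL cells (Homo sapiens), read by microscopy (a higher number here means that more compound is tolerated, a lower number that less compound is tolerated), compound 1 gives > 400000 nM, which is a limit of the assay and not a number. Compound 2 `CCCCC#Cc1cc2cn(COCCO)c(=O)nc2o1` has hex-1-yn-1-yl in place of butyl on an aromatic carbon. In this assay compound 2 gives > 100000 nM, again a limit rather than a number. The step that the two limits leave unreadable from compound 1 to compound 2 is therefore unreadable in size and direction. Compound 3 `CC(C)[C@@H](NC(N)=O)C(=O)O`, built on a different scaffold, gives > 400000 nM in this assay, also a limit. Across the three values, the limit of > 400000 nM in this assay, at which 2 of the 3 values shown sit, and (the limit of > 100000 nM in this assay, at which 1 of the 3 values shown sits); nothing here is a read number, so compound 1 stands at the upper limit with no ranking among the three possible.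

Compound 4 `CCCCCCCCc1cc2cn(COCCO)c(=O)nc2o1` is the next chain member: butyl in place of hydrogen on a saturated chain carbon, four bonds along the chain from an aromatic carbon. Among the compounds with values here, the only measured step on this core, from compound 1 to compound 2, gives no usable size, so no direction is indicated for the change to compound 4. The step of an at least 1.3-fold lower number from compound 1 to compound 4 (0.12 log units; that floor lies within the scatter) is expected to stay within the scatter, with the outcome most likely another limit. Compound 4 is expected to give 300000 nM in this assay, within 60000 nM to 400000 nM.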

Compound 4, minimum cytotoxic concentration: >= 80000 nM
Compound 4 was reported as a limit (the forecaster's own chance of this, stated with the estimate: 65%); the middle value does not contradict the limit.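

In this assay, compound 4 is reported only as a limit, as is compound 1, so the step between these two compounds cannot be read in either size or direction. The compounds shown leave open whether the chain on the shared core changes the minimum cytotoxic concentration at all, with no read number yet on this core.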